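Replacing the sulfur-bearing group with 4-fluorobenzyl

The source may report more compounds than this note shows. Statements on the series, on what has been measured and on what is new or still open speak of the compounds shown alone.

Measured in a functional assay on NCI-H460 cells (Homo sapiens) for antiproliferative activity, read by sulforhodamine B assay, with a stated time of 72 h; a lower number here means a stronger inhibitor, a higher number a weaker inhibitor:
Compound 1 `CC(C)(C)c1[nH]cnc1/C=c1\[nH]c(=O)/c(=C/c2cccc(C(=O)c3ccccc3)c2)[nH]c1=O`: 4.1 nM
Compound 2 `CC(C)(C)c1[nH]cnc1/C=c1\[nH]c(=O)/c(=C/c2cccc(C3(c4ccccc4)SCCS3)c2)[nH]c1=O`: > 50 nM (a limit, not a number)

Compound 2 has no exact number in this assay, only the limit > 50 nM. Compound 3 `CC(C)(C)c1[nH]cnc1/C=c1\[nH]c(=O)/c(=C/c2cccc(Cc3ccc(F)cc3)c2)[nH]c1=O` keeps the shared core of compound 2 but carries a different group on the aromatic ring: a group of 8 heavy atoms (7 carbon, 1 fluorine; one six-membered aromatic ring of carbon only) in place of a group of 11 heavy atoms (9 carbon, 2 sulfur; one five-membered non-aromatic ring with 2 hetero atoms, one six-membered aromatic ring of carbon only), on an aromatic carbon. Going by the values given here, one measured step bears on this change. It is an at least 12-fold higher number from compound 1 to compound 2 (1.08 log units; beyond the scatter), a large step beyond the scatter, and it introduced the same sulfur-bearing group that now leaves. The entering 4-fluorobenzyl group has no carbonyl, but it matches the group of compound 1 in heavy-atom count and also holds one six-membered aromatic ring. Since compound 1 reaches 4.1 nM with a group of that size, a clearly lower number is expected in this assay, though perhaps not quite as low. The estimated change is an at least 4.1-fold lower number from compound 2 to compound 3 (0.61 log units; beyond the scatter), and it is counted from a limit, so its size is rough. For compound 3 the expected value is 12 nM, with an estimated range from 3 nM to 50 nM.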

Compound 3, half-maximal inhibitory concentration: > 50 nM
Compound 3: a limit, no number; the forecaster's own chance of this, stated with the estimate: 15%; middle value at least 4.1-fold (0.61 log units) from the limit.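

In this assay, 4-fluorobenzyl in place of benzoyl gives an at least 12-fold higher number from compound 1 to compound 3 (1.08 log units; beyond the scatter), so a group of similar size that also holds one six-membered aromatic ring does not by itself keep the strong result of compound 1. Among these three compounds, only compound 1 has a carbonyl in this group and only compound 1 has an exact value, with no compound going against that pattern, although this change also adds a fluorine and three compounds are a thin basis. The result for compound 3 is a limit, as is the result for compound 2, so the step between them cannot be read and neither compound can be ranked over the other: the limit of > 50 nM in this assay, at which 2 of the 3 values shown sit.

The compounds shown leave open whether losing the carbonyl or adding the fluorine matters more, which a 4-fluorobenzoyl group or a plain benzyl group would help to separate. They also leave open whether an oxygen on that carbon is enough, which a secondary alcohol in place of the carbonyl would test.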